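Series notes: 4-methylphenyl to 4-ethylphenyl

The source may hold more compounds than are shown below. What is called first, only, known or untested is meant among the compounds shown, and "the series" means these compounds.

Measured in a functional assay on A-431 cells (Homo sapiens) for cytotoxicity; a lower number here means that less compound is needed, a higher number that more compound is needed for the effect:
- compound 1 `COC1=C(C)C(=O)/C(=C(O)/C=C/c2cccc3ccccc23)C(=O)C1(C)C`: 4.1 ug/mL
- compound 2 `CCC1=C(OC)C(CC)(CC)C(=O)C(C(=O)/C=C/c2ccccc2)=C1O`: 5.4 ug/mL
- compound 3 `CCC1=C(OC)C(CC)(CC)C(=O)C(C(=O)/C=C/c2ccc(C)cc2)=C1O`: 10.3 ug/mL

Compound 3, at 10.3 ug/mL, lies within the scatter of compound 2. The gap between compound 3 and compound 1 is beyond the scatter, with the lower number belonging to compound 1.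

Compound 4 `CCC1=C(OC)C(CC)(CC)C(=O)C(C(=O)/C=C/c2ccc(CC)cc2)=C1O` is still to be measured. It differs from compound 3 by methyl in place of hydrogen on a saturated chain carbon bound to an aromatic carbon, so 4-methylphenyl becomes 4-ethylphenyl: methyl in place of hydrogen on a saturated chain carbon bound to an aromatic carbon.

For the measured compounds named here, one measured step bears on this change: a 1.9-fold higher number from compound 2 to compound 3 (0.28 log units; within the scatter). Going by the values given here, that step placed methyl in place of hydrogen on an aromatic carbon, so it is only a partial guide, and no measured step covers the present change itself. With so little evidence, no shift beyond the scatter is expected in this assay.

The expected step is a 1.1-fold higher number from compound 3 to compound 4 (0.03 log units; within the scatter).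

For compound 4 the estimated value is 11 ug/mL, with an expected range of 5.5 ug/mL to 21 ug/mL.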

Compound 4, concentration for half-maximal effect: 9.8 ug/mL
Beside the measured number, compound 4's estimate is 1.1-fold (0.05 log units) above it; low and high end bracket the measured number.
By their numbers in this assay, from the lowest: compounds 1, 2, 4 and 3 (each within the scatter of the next, the first and the last beyond it).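

In this assay, for the compounds shown here, the step from 4-methylphenyl to 4-ethylphenyl gives a 1.1-fold lower number from compound 3 to compound 4 (0.02 log units; within the scatter) and so adds the first reading at the saturated chain carbon bound to an aromatic carbon: a methyl there brings no shift that can be told from the scatter. Set against the unsubstituted phenyl of compound 2, the ethyl group gives a 1.8-fold higher number from compound 2 to compound 4 (0.26 log units; within the scatter) and, like the methyl group of compound 3, does not separate from hydrogen at this position of the ring. The data shown offer no measurement that would account for this flat result.

From the compounds shown here alone, whether a longer chain such as butyl would stay within the scatter remains open. So does the outcome for an amine or a carboxylic acid at the same place, since only small alkyl groups and hydrogen are covered here.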